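A Piperazine in Place of the Pyridyl Amine

The source may report more compounds than this note shows. Statements on the series, on what has been measured and on what is new or still open speak of the compounds shown alone.

Three compounds sharing one core have been examined in a functional assay on MGC-803 cells (Homo sapiens) for antiproliferative activity, read by CCK-8 assay, with a stated time of 72 h, tested at 2 uM; a higher number here means a stronger effect of the compound at the concentration tested, a lower number a weaker effect. Compound 1 `CCN(Cc1ccncc1)C(=S)SCc1ccc(C(=O)Nc2ccccc2N)cc1` gives 71.6%. Compound 2 `CN(Cc1ccncc1)C(=S)SCc1ccc(C(=O)Nc2ccccc2N)cc1` gives 38.1%, and compound 3 `CN(C(=S)SCc1ccc(C(=O)Nc2ccccc2N)cc1)c1cccnc1` gives 46.1%. Compound 3 thus stands second of the three: its gap to compound 2 is within the scatter, while the fall a number 25.5 percentage points lower from compound 1 to compound 3 (beyond the scatter) lies beyond it. The next compound, compound 4 `CN1CCN(C(=S)SCc2ccc(C(=O)Nc3ccccc3N)cc2)CC1`, differs from compound 3 at one place: 4-methylpiperazin-1-yl in place of methyl(pyridin-3-yl)amino on a thiocarbonyl carbon. Within the data shown here, two measured steps bear on this change. Replacing the whole amino group on the thiocarbonyl carbon, a number 25.5 percentage points lower from compound 1 to compound 3 (beyond the scatter), was modest and downward, whereas exchanging only the ring on the amide-type nitrogen, a number 8 percentage points higher from compound 2 to compound 3 (within the scatter), stayed within the scatter. Changes at this place have therefore ranged from no effect to a modest loss, and the large step of a number 33.5 percentage points lower from compound 1 to compound 2 (beyond the scatter) concerns a different place. A step of a number 6.1 percentage points lower from compound 3 to compound 4 (within the scatter) is expected in this assay for compound 4. Compound 4 is therefore estimated at 40%, with a range from 20% to 62%.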

Compound 4, a percentage reported as inhibition, at one concentration (the size of the read-out at that concentration, not a potency): 29.6%
Beside the measured number, compound 4's estimate is 10.4 percentage points above it; low and high end bracket the measured number.
By their numbers in this assay, from the lowest: compounds 4, 2 and 3 (each within the scatter of the next, the first and the last beyond it); then compound 1.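

In this assay, the 4-methylpiperazin-1-yl group brings a change at the thiocarbonyl carbon that is beyond the scatter, a number 16.5 percentage points lower from compound 3 to compound 4 (beyond the scatter), whereas the earlier exchange between compound 2 and compound 3 stayed within it. The same group does not separate from the chain-linked pyridine, a number 8.5 percentage points lower from compound 2 to compound 4 (within the scatter), so the size of the effect depends on which amino group it replaces. Among these compounds, the step of a number 42 percentage points lower from compound 1 to compound 4 (beyond the scatter) is the largest at this place, and ethyl((pyridin-4-yl)methyl)amino remains the only group here that stands clear of all the others.

As far as these compounds go, whether a 4-ethylpiperazin-1-yl or a morpholin-4-yl group on the thiocarbonyl carbon would give a different number remains open. Nothing available accounts for any of these steps.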